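This account rests on a few compounds, and the source may have more. Where it says the series, first, only, none or still open, it means among the compounds named here.

Working notes on the vanillyl amide series. Compound 1 `CCCCCC[C@@H](O)C/C=C\CCCCCCCCSCCC(=O)NCc1ccc(O)c(OC)c1` is run in an assay on HEK293 cells for antagonist activity at transient receptor potential cation channel subfamily V member 2 (Rattus norvegicus), read by fluorescence and calcium flux, with a stated time of 5 min (on this read-out lower numbers stand for stronger inhibition and higher numbers for weaker inhibition), and in this assay compound 1 reaches only the limit > 10000 nM rather than a number. Compound 2 `CCCCCCCC/C=C\CCCCCCCC[Se]CCC(=O)NCc1ccc(O)c(OC)c1`, with its selenium-containing unsaturated chain, gives 1800 nM in this assay. Compound 3 `CCCCCCCCCCCCCCCC(=O)NCc1ccc(O)c(OC)c1`, the saturated straight-chain amide, also returns only the limit > 10000 nM in this assay. Compound 3 thus stands at the boundary of the measurement, the position where most of the series sits (the limit of > 10000 nM in this assay, at which 2 of the 3 values shown sit), and no number is available for it.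

Compound 4 `CCCCCCCCCCCCCCCCCCCC(=O)NCc1ccc(O)c(OC)c1` differs from compound 3 by butyl in place of hydrogen on a saturated chain carbon, ten or more bonds along the chain from a carbonyl carbon. For the measured compounds named here, no step between two measured compounds is available for this change, so its size is judged from the structures alone. The expected step in this assay is a step that the limit leaves unreadable from compound 3 to compound 4, that is, none beyond the scatter. Compound 4 is estimated at 15000 nM, with a range from 5000 nM to 50000 nM, and a limit rather than a number is again the likelier outcome.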

Compound 4, half-maximal inhibitory concentration: 3100 nM
For compound 4 the middle estimate is 4.8-fold (0.68 log units) above the measured one; the measured number lies below the stated range.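

Butyl in place of hydrogen on a saturated chain carbon gives the first readable step in the series in this assay: an at least 3.2-fold lower number from compound 3 to compound 4 (0.50 log units; beyond the scatter). This position therefore responds to the change, although it lies far along the chain from the carbonyl carbon. Compound 4 also shows that a fully saturated straight chain, with no selenium, sulfur or double bond in it, can give a number rather than a limit.

Going by these compounds, the full size of the step stays open because compound 3 sits at a limit of the assay: the limit of > 10000 nM in this assay, at which 2 of the 4 values shown sit. Whether a longer chain would lower the number further, or a carboxylic acid at the chain end would keep it, the compounds shown do not tell.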